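Spirocyclic amides: piperazine amide as next step

The source may hold more compounds than are shown below. What is called first, only, known or untested is meant among the compounds shown, and "the series" means these compounds.

Compound 1 `CC(C)(C)c1ccc(C(=O)N2CCC3(CC2)C(=O)N(CC(=O)N2CCCCC2CCO)CN3c2ccccc2)cc1` gives 6100 nM in an assay on HEK293 cells for displacement of a labelled ligand from NPC1-like intracellular cholesterol transporter 1 (Homo sapiens); a higher number here means a weaker inhibitor, a lower number a stronger inhibitor. Compound 2 `COC(=O)CCCNC(=O)CN1CN(c2ccccc2)C2(CCN(C(=O)c3ccc(C(C)(C)C)cc3)CC2)C1=O` is recorded as "not determined" (no result reported) in this assay, so no number stands for it there. Compound 3 `CC(C)(C)c1ccc(C(=O)N2CCC3(CC2)C(=O)N(CC(=O)N2CCNCC2)CN3c2ccccc2)cc1` differs from compound 2 by piperazin-1-yl in place of (3-(methoxycarbonyl)propyl)amino on a carbonyl carbon. Among the compounds with values here, no measured step connects the two, and the only reference is compound 1 at 6100 nM with a different amide partner, so no direction can be drawn for this assay and a step of small size, within the scatter, is the plain expectation. Compound 3 is therefore expected to sit near 5000 nM, with a range from 1500 nM to 20000 nM.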

Compound 3, half-maximal inhibitory concentration: 22000 nM
For compound 3 the middle estimate is 4.4-fold (0.64 log units) below the measured one, and the stated range ends below it.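

In this assay, piperazin-1-yl in place of 2-(2-hydroxyethyl)piperidin-1-yl on the carbonyl carbon gives a 3.6-fold higher number from compound 1 to compound 3 (0.56 log units; beyond the scatter), so this amide partner does affect the read-out and the piperazine amide is the weaker of the two. The step from compound 2 to compound 3 cannot be read, as compound 2 has no number. Nothing at hand explains the step.

Plain piperidin-1-yl would show whether the hydroxyethyl chain or the second ring nitrogen accounts for the step. Also open, from the compounds shown here alone, is whether a 2-hydroxyethyl or acetyl group on the piperazine restores the level of compound 1.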